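Swapping Nitro for Pentafluoroethyl on Two Aortic Relaxants

The compounds below may be only part of what the source reports. "The series", "measured", "known", "first", "only" and "open" are said of these compounds alone.

Compound 1 `O=C1CCCCN1[C@@H]1c2cc([N+](=O)[O-])ccc2OC(CF)(CF)[C@H]1O` and compound 2 `O=C1CCCCN1[C@@H]1c2cc(C(F)(F)C(F)(F)F)ccc2OC(CF)(CF)[C@H]1O` share one core and differ only in that (1,1,2,2,2-pentafluoroethyl in place of nitro on an aromatic carbon). In a functional assay (aorta) with Rattus norvegicus as the target (on this read-out lower numbers stand for an effect already at smaller amounts and higher numbers for an effect only at larger amounts of compound), compound 1 gives 2.75 nM, and compound 2 gives 3.89 nM; the step of a 1.4-fold higher number from compound 1 to compound 2 (0.15 log units; within the scatter).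

Compound 3 `O=[N+]([O-])c1ccc2c(c1)C(c1cccc[n+]1[O-])=CC(CF)(CF)O2` is built on a different core; the difference between the two cores is not broken down here. In this assay compound 3 gives 1.74 nM, a number within the scatter of that of compound 1 but beyond the scatter of that of compound 2.

Compound 4 `[O-][n+]1ccccc1C1=CC(CF)(CF)Oc2ccc(C(F)(F)C(F)(F)F)cc21` differs from compound 3 in that (1,1,2,2,2-pentafluoroethyl in place of nitro on an aromatic carbon), the same change as from compound 1 to compound 2, placed in the same way. A step of about the same size is expected, a 1.4-fold higher number from compound 3 to compound 4 (0.14 log units; within the scatter), because the earlier step of a 1.4-fold higher number from compound 1 to compound 2 (0.15 log units; within the scatter) stayed within the scatter. Compound 4 is therefore estimated at 2.4 nM, with a likely range from 1.2 nM to 5 nM.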

Compound 4, half-maximal effective concentration: 1.7 nM
Compound 4: the middle estimate sits 1.4-fold (0.15 log units) above what was measured; low and high end bracket the measured number.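

On the second core, putting 1,1,2,2,2-pentafluoroethyl in place of nitro comes with a 1.0-fold lower number from compound 3 to compound 4 (0.01 log units; within the scatter) in this assay. Neither step stands out from the scatter, and the two cores do not differ measurably in how they take this change: the same change on two cores in this assay, a 1.4-fold higher number (0.15 log units; within the scatter) from compound 1 to compound 2 and a 1.0-fold lower number (0.01 log units; within the scatter) from compound 3 to compound 4, 1.4-fold (0.16 log units) apart, within the scatter of two such steps. This supports carrying the change between these two cores in this assay, but two pairs do not show that it would hold on other cores, and they do not explain why the numbers stay so close.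

The compounds shown leave open whether other groups on the same aromatic carbon, such as an amine, a nitrile or a carboxylic acid, would also stay within the scatter. They also leave open whether the match would survive in any other assay.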